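This account rests on a few compounds, and the source may have more. Where it says the series, first, only, none or still open, it means among the compounds named here.

Compounds 1, 2 and 3 share one core and differ only in the group on the aromatic nitrogen. In a functional assay on A549 cells (Homo sapiens) for antiproliferative activity, read by MTT assay, with a stated time of 72 h (on this read-out lower numbers stand for stronger inhibition and higher numbers for weaker inhibition), compound 1 `O=C(Nc1ccc(Oc2ccnc3[nH]ccc23)cc1)c1cc2cccnc2n(-c2ccccc2)c1=O` gives 360 nM, compound 2 `O=C(Nc1ccc(Oc2ccnc3[nH]ccc23)cc1)c1cc2cccnc2n(-c2ccc(Br)cc2)c1=O` gives 280 nM, and compound 3 `COc1ccc(-n2c(=O)c(C(=O)Nc3ccc(Oc4ccnc5[nH]ccc45)cc3)cc3cccnc32)cc1` gives 930 nM, the highest of the three numbers. The step of a 2.6-fold higher number from compound 1 to compound 3 (0.41 log units; beyond the scatter) and the step of a 3.3-fold higher number from compound 2 to compound 3 (0.52 log units; beyond the scatter) both point the same way, while a 1.3-fold lower number from compound 1 to compound 2 (0.11 log units; within the scatter) is within the scatter. Compound 4 `O=C(Nc1ccc(Oc2ccnc3[nH]ccc23)cc1)c1cc2cccnc2n(-c2ccc(F)c(Cl)c2)c1=O` carries 3-chloro-4-fluorophenyl in place of 4-methoxyphenyl on an aromatic nitrogen. Since the two halogen-bearing analogues, compounds 1 and 2, sit below compound 3, compound 4 is expected to return to that lower range, with an expected step of a 2.9-fold lower number from compound 3 to compound 4 (0.46 log units; beyond the scatter). The estimate for compound 4 in this assay is 320 nM, between 150 nM and 700 nM.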

Compound 4, half-maximal inhibitory concentration: 680 nM
Compound 4: middle estimate off by 2.1-fold (0.33 log units), on the low side, within the range that was stated.
By their numbers in this assay, from the lowest: compounds 2, 1, 4 and 3 (each within the scatter of the next, the first and the last beyond it).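

In this assay the 3-chloro-4-fluorophenyl group on this aromatic nitrogen cannot be told apart from 4-methoxyphenyl (a 1.4-fold lower number from compound 3 to compound 4 (0.14 log units; within the scatter)) or from phenyl (a 1.9-fold higher number from compound 1 to compound 4 (0.28 log units; within the scatter)). It separates only from 4-bromophenyl (a 2.4-fold higher number from compound 2 to compound 4 (0.39 log units; beyond the scatter)), so a halogen on this ring does not by itself bring compound 4 level with compound 2. No measurement shown here offers an explanation for this gap.

On these data alone, whether the chlorine or the fluorine of compound 4 matters more remains open. So does the result for an aminophenyl group, a carboxylic acid on this ring or a longer alkyl chain at this nitrogen.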